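Replacing 3-methylphenyl with 4-bromophenyl in compound 2

The source may hold more compounds than are shown below. What is called first, only, known or untested is meant among the compounds shown, and "the series" means these compounds.

Of the compounds shown here, three built on a shared core have been measured in a functional assay (strain AB) with Danio rerio as the target, read by microscopy, with a stated time of 1 h; a higher number here means that more compound is needed for the effect, a lower number that less compound is needed. Compound 1 (`CC(C)(C)OC(=O)CCCCC[N+]1(C)CCc2c(sc(NC(=O)Nc3ccc(Cl)cc3)c2C(N)=O)C1`) gives 110 nM, and compound 3 (`NC(=O)c1c(NC(=O)Nc2ccc(Cl)cc2)sc2c1CCN(CC1CCCC1)C2`) gives 1830 nM. Compound 2 (`CCN1CCc2c(sc(NC(=O)Nc3cccc(C)c3)c2C(N)=O)C1`) gives 13000 nM, the highest number of the three and beyond the scatter from both of the others, so it is the least potent of this small set.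

Compound 4 (`CCN1CCc2c(sc(NC(=O)Nc3ccc(Br)cc3)c2C(N)=O)C1`) has not yet been measured. It differs from compound 2 by 4-bromophenyl in place of 3-methylphenyl on an amide-type nitrogen. Going by the values given here, no two measured compounds differ in one place only, so the data do not isolate this change. Among the compounds with values here, the only guidance is loose: compound 3 has a chlorophenyl group on that nitrogen but also differs from compound 2 elsewhere. Compound 3 gives 1830 nM. On that limited basis, a moderate step towards a lower number is expected, although a much smaller one remains possible. The expected step is a 3.3-fold lower number from compound 2 to compound 4 (0.51 log units; beyond the scatter). For compound 4 the estimated value is 4000 nM, with an expected range of 1300 nM to 12000 nM.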

Compound 4, half-maximal effective concentration: 3130 nM
The estimate for compound 4 lay 1.3-fold (0.11 log units) above the measured number; the range from low to high includes it.
By their numbers in this assay, from the lowest: compound 1; then compounds 3 and 4 (each within the scatter of the next); then compound 2.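

With 4-bromophenyl in place of 3-methylphenyl on an amide-type nitrogen, this assay gives a 4.2-fold lower number from compound 2 to compound 4 (0.62 log units; beyond the scatter). Going by these compounds alone, this is the first change in the set that stands alone, and it shows that the number responds to the group on this nitrogen, even though the step is modest. The two groups match in heavy-atom count and in hydrogen-bond donors and acceptors, so these counts do not separate them, and no measurement available here explains the step.

Bromine enters and methyl leaves in one change, so the compounds shown cannot tell whether the step comes from gaining the one, losing the other, or where each group sits on the ring, a question that a plain phenyl group on this nitrogen could begin to answer. From the compounds shown here alone, it also remains open whether the same step would hold with a different group elsewhere on the shared core, such as a longer chain or an amine.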